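One Ring Swap, Carried From One Core to Another

The compounds below may be only part of what the source reports. "The series", "measured", "known", "first", "only" and "open" are said of these compounds alone.

Compound 2 `COc1cc2ncnc(NNC(=S)NC(=O)c3ccc(C)cc3)c2cc1OC` and compound 1 `COc1cc2ncnc(NNC(=S)NC(=O)c3ccccc3Cl)c2cc1OC` share one core and differ only at the carbonyl carbon. In a functional assay on CNE-2 cells (Homo sapiens) for cytotoxicity, read by MTT assay, with a stated time of 72 h (a higher number here means a weaker inhibitor, a lower number a stronger inhibitor), compound 2 gives 33300 nM, and compound 1 gives 9670 nM. The change between them is 2-chlorophenyl in place of 4-methylphenyl on a carbonyl carbon, and it made a 3.4-fold lower number from compound 2 to compound 1 (0.54 log units; beyond the scatter). Compound 3 `Cc1ccc(C(=O)NC(=S)NNc2ncnc3ccccc23)cc1` is built on a different core; the difference between the two cores is not broken down here. In this assay compound 3 gives 17200 nM, which lies within the usual scatter of the value of compound 1. Compound 4 `O=C(NC(=S)NNc1ncnc2ccccc12)c1ccccc1Cl` has not been measured in this assay. Among the measured compounds shown here, it differs from compound 3 by 2-chlorophenyl in place of 4-methylphenyl on a carbonyl carbon, the same change at the same place as the one that separates compound 2 from compound 1. Compound 4 is therefore expected to show a step of a 3.1-fold lower number from compound 3 to compound 4 (0.50 log units; beyond the scatter). That expectation rests on one precedent only, because a 3.4-fold lower number from compound 2 to compound 1 (0.54 log units; beyond the scatter) was observed on the other core, and a single instance carries real uncertainty. Compound 4 is estimated at 5500 nM, with a likely range from 2000 nM to 15000 nM.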

Compound 4, half-maximal inhibitory concentration: 6090 nM
For compound 4 the middle estimate is 1.1-fold (0.04 log units) below the measured one; the range from low to high includes it.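

In this assay, placing 2-chlorophenyl in place of 4-methylphenyl on the carbonyl carbon gave a 2.8-fold lower number from compound 3 to compound 4 (0.45 log units; beyond the scatter), so the change seen on the first core also appeared on the second. The two steps point the same way and cannot be told apart in size: the same change on two cores in this assay, a 3.4-fold lower number (0.54 log units; beyond the scatter) from compound 2 to compound 1 and a 2.8-fold lower number (0.45 log units; beyond the scatter) from compound 3 to compound 4, 1.2-fold (0.09 log units) apart, within the scatter of two such steps. This shows that the change carried over between these two cores in this one assay, but two matched pairs do not show that it would carry to any further core, and they do not explain why the step arises.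

The compounds shown leave open how other groups on the carbonyl carbon would behave, such as a pyridine ring, a saturated ring like cyclohexyl, or a phenyl ring bearing an amine or a carboxylic acid. They also leave open whether the same step would hold in cells other than the CNE-2 line.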